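A few compounds are considered here, and "the series" means these few. Any claim that something is new, unique, unknown or untested is made for them only; others in the source may bear on it.

Compound 1, `COc1cc(Cl)cc(-c2nn(-c3cccc(NC(=O)Nc4ccc(Cl)c(C(F)(F)F)c4)c3)cc2-c2ccncc2)c1`, gives -15% in a functional assay on PC-3 cells (Homo sapiens) for inhibition, read by sulforhodamine B assay, with a stated time of 48 h, tested at 100 uM; a higher number here means a weaker effect of the compound at the concentration tested, a lower number a stronger effect.
Compound 2, `COc1cc(Cl)cc(-c2nn(-c3cccc(NC(=O)Nc4cc(C(F)(F)F)cc(C(F)(F)F)c4)c3)cc2-c2ccncc2)c1`, gives -44%.
Compound 3, `COc1cc(Cl)cc(-c2nn(-c3cccc(NC(=O)Nc4ccc(Cl)c(Cl)c4)c3)cc2-c2ccncc2)c1`, gives -24%.

Of these three numbers compound 3 holds the second highest; compound 1 sits close to it, within the usual scatter, while compound 2 sits further off, lower by a margin beyond the scatter. Compound 4, `COc1cc(Cl)cc(-c2nn(-c3cccc(NC(=O)Nc4cccc(C(F)(F)F)c4)c3)cc2-c2ccncc2)c1`, is not yet measured. It differs from compound 3 in a single place: 3-(trifluoromethyl)phenyl in place of 3,4-dichlorophenyl on an amide-type nitrogen. Among the measured compounds shown here, only one measured step bears on this kind of exchange: a number 9 percentage points lower from compound 1 to compound 3 (within the scatter), a change too small to count. For the measured compounds named here, that step swapped a chloro for a trifluoromethyl while keeping a second substituent; the step to compound 4 also drops the second chloro, for which no measured pair gives guidance. Going by the values given here, with one uninformative step as the sole precedent, the expectation is no change beyond the scatter, with the estimated step from compound 3 being a number 6 percentage points higher from compound 3 to compound 4 (within the scatter). Compound 4 is therefore expected to give about -18%, within a range from -40% to 5%.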

Compound 4, a percentage reported as activity, at one concentration (the size of the read-out at that concentration, not a potency): -35%
For compound 4 the middle estimate is 17 percentage points above the measured one, and the stated range covers the measured number.
By their numbers in this assay, from the lowest: compounds 2 and 4 (each within the scatter of the next); then compounds 3 and 1 (each within the scatter of the next).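

Among the compounds shown here, this exchange is the first on this amide-type nitrogen to move the number beyond the scatter: a number 11 percentage points lower from compound 3 to compound 4 (beyond the scatter), a modest step towards a stronger effect. The single 3-(trifluoromethyl)phenyl group thus gives up nothing in this assay by lacking a second substituent, and the outcome depends on which substituent goes: hydrogen in place of chloro gives a number 20 percentage points lower from compound 1 to compound 4 (beyond the scatter), also modest and beyond the scatter, whereas hydrogen in place of trifluoromethyl gives a number 9 percentage points higher from compound 2 to compound 4 (within the scatter), within the scatter. Nothing measured here explains why these exchanges differ.

Whether the trifluoromethyl itself matters remains open, since no compound shown carries hydrogen, a nitrile or an amine in its place. Each comparison also rests on a single concentration, so the steps say nothing about potency.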